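The compounds below may be only part of what the source reports. "The series", "measured", "known", "first", "only" and "open" are said of these compounds alone.

Working notes on the series. Compound 1 `CN1C(=O)C2(C(C#N)=C(N)Oc3cc4oc(-c5ccccc5)cc(=O)c4c(O)c32)c2cccc(Cl)c21`, compound 2 `Cc1cccc2c1N(Cc1ccccc1)C(=O)C21C(C#N)=C(N)Oc2cc3oc(-c4ccccc4)cc(=O)c3c(O)c21` and the still unmeasured compound 3 `N#CC1=C(N)Oc2cc3oc(-c4ccccc4)cc(=O)c3c(O)c2C12C(=O)N(Cc1ccccc1)c1c(Cl)cccc12` share one core. In a functional assay on K562 cells (Homo sapiens) for antiproliferative activity, read by MTT assay, with a stated time of 48 h (on this read-out higher numbers stand for weaker inhibition and lower numbers for stronger inhibition), compound 1 gives 41400 nM. For compound 2 this assay reports only a limit, > 50000 nM, not a number. Compound 2 thus stands at the limit of > 50000 nM in this assay, at which 1 of the 2 values shown sits. Compound 3 differs from compound 2 by chloro in place of methyl on an aromatic carbon. Going by the values given here, no measured step covers this exchange; compound 1, which carries the chloro, and compound 2, which carries the methyl, both sit at the weak end of this assay, and that is all the two values show. The step that the limit leaves unreadable from compound 2 to compound 3 is expected to stay within the usual scatter, with no clear direction. Compound 3 is therefore estimated at about 60000 nM, within 30000 nM to 150000 nM.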

Compound 3, half-maximal inhibitory concentration: 47800 nM
For compound 3 the middle estimate is 1.3-fold (0.10 log units) above the measured one; low and high end bracket the measured number.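

In this assay, chloro in place of methyl on an aromatic carbon gives an at least 1.0-fold lower number from compound 2 to compound 3 (0.01 log units; that floor lies within the scatter), so this exchange now has a number on one side, and that number shows no clear gain in inhibition. Compound 2 carries a limit and not a number, so the full size of this step cannot be read: the limit of > 50000 nM in this assay, at which 1 of the 3 values shown sits. With chloro held fixed, phenyl in place of hydrogen on a saturated chain carbon bound to an amide-type nitrogen in a ring gives a 1.2-fold higher number from compound 1 to compound 3 (0.06 log units; within the scatter), so this second exchange stays within the scatter in this assay.

On these data alone, whether fluoro, methoxy or an amine on the same aromatic carbon would shift the number remains open. So does the effect of a carboxylic acid or a longer chain on the amide-type nitrogen.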